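This account rests on a few compounds, and the source may have more. Where it says the series, first, only, none or still open, it means among the compounds named here.

In a physicochemical assay, read by spectrophotometry, with a stated time of 15 min (a higher number here means a weaker inhibitor, a lower number a stronger inhibitor), compound 2 (`COc1cc(/C=N/NC(=O)CCCc2nc3ccccc3c(=O)[nH]2)cc(O)c1O`) gives 80000000 nM. Compound 3 (`O=C(CCc1nc2ccccc2c(=O)[nH]1)N/N=C/c1cc(O)c(O)c(O)c1`) gives 45000000 nM, which cannot be separated from compound 2 because the two values lie within the scatter. Compound 1 (`COc1cc(/C=N/NC(=O)CCCc2nc3ccccc3c(=O)[nH]2)cc(OC)c1O`) gives 225000000 nM, a number clearly higher than that of compound 2. Compound 3 differs from compound 2 in more than one place, so it offers no clean comparison.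

The next structure is compound 4 (`O=C(CCCc1nc2ccccc2c(=O)[nH]1)N/N=C/c1ccc(O)c(O)c1`), which carries hydrogen in place of methoxy on an aromatic carbon.

Within the data shown here, one measured step bears on this change, and only indirectly. It is a 2.8-fold lower number from compound 1 to compound 2 (0.45 log units; beyond the scatter), with hydrogen in place of methyl on an oxygen on an aromatic ring. That step is modest and leaves the oxygen in place, whereas here the whole methoxy leaves. Among the measured compounds shown here, no measured pair shows this exact change, so its direction is not settled by the data. No shift beyond the scatter is therefore expected in this assay, and the expected step is a 1.1-fold higher number from compound 2 to compound 4 (0.05 log units; within the scatter) with low confidence in its direction. For compound 4 the estimated value is 90000000 nM, with 35000000 nM as the expected lower end and 230000000 nM as the expected upper end.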

Compound 4, half-maximal inhibitory concentration: 75000000 nM
For compound 4 the middle estimate is 1.2-fold (0.08 log units) above the measured one; the measured number falls inside the stated range.
By their numbers in this assay, from the lowest: compounds 3, 4 and 2 (each within the scatter of the next); then compound 1.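

In this assay, among these compounds, this is the first direct reading of the full loss of the methoxy group ortho to a hydroxy group, and the replacement by hydrogen gives a 1.1-fold lower number from compound 2 to compound 4 (0.03 log units; within the scatter). On this aromatic carbon, then, the methoxy group can give way to hydrogen without a separable change in the number, with compound 4 at 75000000 nM, whereas the earlier step on an aromatic oxygen, a 2.8-fold lower number from compound 1 to compound 2 (0.45 log units; beyond the scatter), lies beyond the scatter. No measurement available here accounts for either step.

Among the compounds shown here, still open is whether an amine or a carboxylic acid on this same aromatic carbon would give a step beyond the scatter, as the single reading here compares only methoxy with hydrogen. For the compounds shown here, also open is how a longer chain in place of the one in compound 4 would read in this assay, and whether the methoxy-to-hydrogen step would stay within the scatter on such a compound.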